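The source may hold more compounds than are shown below. What is called first, only, known or untested is meant among the compounds shown, and "the series" means these compounds.

Of the compounds shown here, three that share one core have been measured in an assay on HEK293 cells for agonist activity at Toll-like receptor 8 (Homo sapiens), read by spectrophotometry; a lower number here means that less compound is needed, a higher number that more compound is needed for the effect. Compound 1 `CCCCNc1nc(N)nc(C)c1CCCN1CCCCCC1` gives 178 nM, the lowest number of the three. Compound 2 `CCCCNc1nc(N)nc(C)c1CCCn1c(C)nc2ccccc21` gives 366 nM, a number beyond the scatter above compound 1. Compound 3 `CCCCNc1nc(N)nc(C)c1C` gives 3280 nM, and its gap to compound 1 is far beyond the scatter, so the group at the end of the chain clearly matters.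

Compound 4 `CCCCNc1nc(N)nc(C)c1CCCC(C)(C)O` differs from compound 1 by 1-hydroxy-1-methylethyl in place of azepan-1-yl on a saturated chain carbon, three bonds along the chain from an aromatic carbon. Among the measured compounds shown here, no measured pair isolates this change, so its size can only be guessed. In this assay a moderate move toward a higher number, beyond the scatter, is expected. Compound 4 is therefore expected to give 600 nM, within 180 nM to 2000 nM, an expected step of a 3.4-fold higher number from compound 1 to compound 4 (0.53 log units; beyond the scatter).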

Compound 4, half-maximal effective concentration: 1220 nM
Beside the measured number, compound 4's estimate is 2.0-fold (0.31 log units) below it, and the stated range covers the measured number.
By their numbers in this assay, from the lowest: compound 1; then compound 2; then compound 4; then compound 3.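

In this assay, the chain end counts even without a ring: 3-hydroxy-3-methylbutyl in place of hydrogen on a saturated chain carbon bound to an aromatic carbon gives a 2.7-fold lower number from compound 3 to compound 4 (0.43 log units; beyond the scatter). Azepan-1-yl nevertheless does better, since 1-hydroxy-1-methylethyl in its place gives a 6.9-fold higher number from compound 1 to compound 4 (0.84 log units; beyond the scatter). Nothing at hand explains either step.

The compounds shown leave open whether the hydroxyl itself contributes, which a plain tert-butyl end would test. They also leave open whether an open-chain amine or a piperidine at this position would match azepan-1-yl.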